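The source may report more compounds than this note shows. Statements on the series, on what has been measured and on what is new or still open speak of the compounds shown alone.

Compound 1 `COc1cc2c(cc1OC)C(c1ccc(Br)cc1)=NNC(=O)C2`: 82.5 umol/kg
Compound 2 `COc1cc2c(cc1OC)C(c1ccc(Br)cc1)=NN=C(S)C2`: 33.3 umol/kg
Compound 3 `COc1cc2c(cc1OC)C(c1ccccc1)=NNC(=O)C2`: 31.8 umol/kg

In a functional assay on the whole organism with Mus musculus as the target (a higher number here means that more compound is needed for the effect, a lower number that less compound is needed), compound 3 gives 31.8 umol/kg, level with compound 2 within the scatter and clearly lower than compound 1. Compound 4 `COc1cc2c(cc1OC)C(c1cccc([N+](=O)[O-])c1)=NNC(=O)C2` keeps the core of compound 3 but carries nitro in place of hydrogen on an aromatic carbon, meta to a large group: nitro in place of hydrogen on an aromatic carbon. Within the data shown here, the one measured step that bears on this change is a 2.6-fold lower number from compound 1 to compound 3 (0.41 log units; beyond the scatter), with hydrogen in place of bromo. Read backwards, it shows a modest rise when a group replaces hydrogen, though with a different group at a different place. A similar modest rise is therefore expected, an estimated 1.5-fold higher number from compound 3 to compound 4 (0.18 log units; within the scatter). For compound 4 the expected value is 48 umol/kg, with an estimated range of 20 umol/kg to 115 umol/kg.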

Compound 4, dose for half-maximal effect: > 120 umol/kg
Compound 4 was reported as a limit; the forecaster's own chance of this, stated with the estimate: 10%; at least 2.5-fold (0.39 log units) between middle value and limit.
By their numbers in this assay, from the lowest: compounds 3 and 2 (each within the scatter of the next); then compound 1. At a limit, above all of these: compound 4.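

Nitro in place of hydrogen on an aromatic carbon, meta to a large group, gives an at least 3.7-fold higher number from compound 3 to compound 4 (0.57 log units; beyond the scatter) in this assay, so with this group at this position clearly more compound is needed for the effect. Among these compounds, the earlier compounds showed a change on this ring only with bromo at a different place, so this is the first reading at this position. The value for compound 4 is a limit of the assay and not a number, so the full size of the step stays unknown: the limit of > 120 umol/kg in this assay, at which 1 of the 4 values shown sits.

On these data alone, what an amine or a carboxylic acid would do at this position stays open. So does whether bromo here would match nitro.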